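Ring methyl added to the fluorinated ortho-tolyl analogue

The source may hold more compounds than are shown below. What is called first, only, known or untested is meant among the compounds shown, and "the series" means these compounds.

Working notes on the series. Of the compounds shown here, two have so far been measured in a functional assay on MCF7 cells (Homo sapiens) for inhibition, read by MTT assay, with a stated time of 72 h; on this read-out lower numbers stand for stronger inhibition and higher numbers for weaker inhibition. Compound 1 `COc1cc2c(Oc3ccc(NC(=O)c4nn(-c5ccccc5)cc(C)c4=O)cc3)ccnc2cc1OCCCCCCC(=O)NO` gives 1610 nM in this assay. Compound 2 `COc1cc2c(Oc3ccc(NC(=O)c4nn(-c5ccccc5C)ccc4=O)c(F)c3)ccnc2cc1OCCCCCCC(=O)NO` gives 3650 nM in this assay, the highest of the two numbers, with compound 1 the nearest at a lower number that lies beyond the usual scatter. For the measured compounds named here, compound 1 and compound 2 differ in more than one place, so no single structural step between them can be read from their two values; only the values themselves are known.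

Compound 3 `COc1cc2c(Oc3ccc(NC(=O)c4nn(-c5ccccc5C)cc(C)c4=O)c(F)c3)ccnc2cc1OCCCCCCC(=O)NO` has not yet been measured. It differs from compound 2 in one place: methyl in place of hydrogen on an aromatic carbon. Compound 1 also carries a methyl on an aromatic carbon of a six-membered aromatic ring with 2 nitrogen and sits at the lower number 1610 nM, but it differs from compound 2 elsewhere as well, so that value cannot be pinned on the methyl alone.

Compound 3 is expected to give 2500 nM in this assay, with a range from 1200 nM to 5500 nM. The expected step of a 1.5-fold lower number from compound 2 to compound 3 (0.16 log units; within the scatter) is small, toward a lower number, and not clearly beyond the scatter.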

Compound 3, half-maximal inhibitory concentration: 2690 nM
Beside the measured number, compound 3's estimate is 1.1-fold (0.03 log units) below it; the measured number falls inside the stated range.
By their numbers in this assay, from the lowest: compounds 1, 3 and 2 (each within the scatter of the next, the first and the last beyond it).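

In this assay, the step for methyl in place of hydrogen on this aromatic carbon, opposite the ring nitrogen, reads a 1.4-fold lower number from compound 2 to compound 3 (0.13 log units; within the scatter) and so cannot be told apart from repeated measurement. For the compounds shown here, this is the first pair that differs in one place, and it gives the first direct reading of this position: with the 2-methylphenyl group and the fluorine kept as in compound 2, adding the methyl leaves the number without a change that can be read. Nothing measured here bears on the reason for this result.

As far as these compounds go, whether a group other than methyl at this carbon, such as an ethyl, a methoxy or an amine, would give a step beyond the scatter remains open. From the compounds shown here alone, whether the methyl gives a similar step in the setting of compound 1 also remains open, and the pairs of compound 1 with compound 2 and with compound 3 cannot be read as steps, since each differs in more than one place.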